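Replacing a ring nitrogen hydrogen with phenyl

The source may hold more compounds than are shown below. What is called first, only, known or untested is meant among the compounds shown, and "the series" means these compounds.

Measured so far:
compound 1 `CC(C(=O)NCc1cc(C(C)(C)C)n[nH]1)c1ccc(NS(C)(=O)=O)c(F)c1`: "not active" (no number reported)
compound 2 `CC(C(=O)NCc1cc(C(C)(C)C)nn1C)c1ccc(NS(C)(=O)=O)c(F)c1`: "not active" (no number reported)
compound 3 `CCCCCn1nc(C(C)(C)C)cc1CNC(=O)C(C)c1ccc(NS(C)(=O)=O)c(F)c1`: 50.2 nM

In an assay on CHO cells for antagonist activity at transient receptor potential cation channel subfamily V member 1 (Homo sapiens), read by FLIPR and calcium flux, with a stated time of 6 min (on this read-out lower numbers stand for stronger inhibition and higher numbers for weaker inhibition), compound 1 gives "not active" (no number reported) and so stands without a number. Compound 2, which carries methyl on the same aromatic nitrogen, also gives "not active" (no number reported) in this assay. Compound 3, with a pentyl chain on that nitrogen, gives 50.2 nM in this assay. Compound 4 `CC(C(=O)NCc1cc(C(C)(C)C)nn1-c1ccccc1)c1ccc(NS(C)(=O)=O)c(F)c1` differs from compound 1 by phenyl in place of hydrogen on an aromatic nitrogen. Since compound 1 reports no number, no step size can be computed; a gain in this assay is expected, because compound 3 gives 50.2 nM with a larger group on that nitrogen. Compound 4 is estimated to reach 150 nM, within 30 nM to 1500 nM.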

Compound 4, inhibition constant: 8 nM
Beside the measured number, compound 4's estimate is 19-fold (1.27 log units) above it; measured number outside the range, below it.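

In this assay, among the compounds shown here, the earlier compounds showed only that pentyl on this aromatic nitrogen gives a number, while hydrogen and methyl give none. Phenyl in place of pentyl now gives a 6.3-fold lower number from compound 3 to compound 4 (0.80 log units; beyond the scatter), so an aromatic ring here does better than a chain. No measurement given here explains why the ring outperforms the chain. From the compounds shown here alone, whether a cyclohexyl ring, which is not aromatic, would match phenyl stays open. So does whether a benzyl group or a pyridine ring would go further still.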